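Swapping a pyridine for a vinyl on a weakly cytotoxic core

The compounds below may be only part of what the source reports. "The series", "measured", "known", "first", "only" and "open" are said of these compounds alone.

Compound 1 `c1ccc(-c2nc(-c3c[nH]c4ccccc34)co2)cc1`: 461000 nM
Compound 2 `c1ccc2c(-c3coc(-c4ccncc4)n3)c[nH]c2c1`: 238000 nM

Going by the values given here, in a functional assay on LNCaP cells (Homo sapiens) for cytotoxicity, read by MTT assay, with a stated time of 48 h (on this read-out lower numbers stand for stronger inhibition and higher numbers for weaker inhibition), compound 2 gives the lowest of the two numbers, and the only measured step, a 1.9-fold lower number from compound 1 to compound 2 (0.29 log units; within the scatter), lies within the scatter, so the two compounds cannot be ranked. Compound 3 `C=Cc1nc(-c2c[nH]c3ccccc23)co1` differs from compound 2 by vinyl in place of pyridin-4-yl on an aromatic carbon. Among the compounds with values here, that change, pyridin-4-yl to vinyl, is not the one measured, so no measured step bears on it directly, and there is no ground for expecting a shift beyond the scatter in either direction. Compound 3 is therefore expected to land near compound 2, at an estimated 350000 nM (range 120000 nM to 1000000 nM), an expected step of a 1.5-fold higher number from compound 2 to compound 3 (0.17 log units; within the scatter).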

Compound 3, half-maximal inhibitory concentration: 530000 nM
The estimate for compound 3 lay 1.5-fold (0.18 log units) below the measured number; the measured number falls inside the stated range.
By their numbers in this assay, from the lowest: compounds 2, 1 and 3 (each within the scatter of the next, the first and the last beyond it).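

In this assay there is a 2.2-fold higher number from compound 2 to compound 3 (0.35 log units; beyond the scatter) when vinyl replaces pyridin-4-yl on this aromatic carbon, a modest step and the first here to clear the scatter. Against phenyl, vinyl gives a 1.1-fold higher number from compound 1 to compound 3 (0.06 log units; within the scatter) and so cannot be ranked, which means that at this position a group with no ring cannot be told apart from phenyl, while pyridin-4-yl and vinyl can.

On these data alone, whether an amine, a carboxylic acid or a longer chain on this carbon would move the number further stays open. No supporting measurement accounts for the step.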